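Cytotoxicity notes: cyclohexyl to 4-chlorophenyl amide replacement

A few compounds are considered here, and "the series" means these few. Any claim that something is new, unique, unknown or untested is made for them only; others in the source may bear on it.

Measured so far:
compound 1 `COc1ccccc1-c1cnc(NC(=O)c2ccc(F)cc2)n1C` — in a toxicity assay on THP-1 cells (Homo sapiens) for inhibition (on this read-out lower numbers stand for higher toxicity in this test and higher numbers for lower toxicity in this test), compound 1 reaches only a limit, > 100000 nM.
compound 2 `COc1ccc(-c2cnc(NC(=O)C3CCCCC3)n2C)cc1` — in this assay compound 2 reaches only a limit, > 100000 nM.
compound 3 `COc1ccc(-c2cnc(NC(=O)c3ccc(F)cc3)n2C(C)C)cc1` — in this assay compound 3 reaches only a limit, > 50000 nM.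

Within the data shown here, compound 2 stands at the limit of > 100000 nM in this assay, at which 2 of the 3 values shown sit, and compound 3 sits at the limit of > 50000 nM in this assay, at which 1 of the 3 values shown sits; no compound shows a number. Among the measured compounds shown here, no two measured compounds differ in a single place, so no measured step can be read.

Compound 4 `COc1ccc(-c2cnc(NC(=O)c3ccc(Cl)cc3)n2C)cc1` differs from compound 2 by 4-chlorophenyl in place of cyclohexyl on a carbonyl carbon.

For the measured compounds named here, with every value so far a limit, no step beyond the scatter is expected in this assay; compound 4 is expected to stay at a limit again, a step that the limit leaves unreadable from compound 2 to compound 4. The estimate for compound 4 is 150000 nM, between 50000 nM and 500000 nM.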

Compound 4, half-maximal cytotoxic concentration: > 100000 nM
Compound 4 gave a limit, no number; the forecaster's own chance of this, stated with the estimate: 85%; the middle value does not contradict the limit.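

Among these compounds, compound 2 and compound 4 both remain at a limit in this assay, and no step between them can be read. The compounds shown leave open whether 4-chlorophenyl in place of cyclohexyl changes toxicity at all.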